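Notes on the step from compound 2 to compound 3

The source may hold more compounds than are shown below. What is called first, only, known or untested is meant among the compounds shown, and "the series" means these compounds.

Measured so far:
compound 1 `Cc1ccccc1CN1CCc2c(sc(NC(=O)c3ccccc3Cl)c2C(N)=O)C1` — > 50000 nM (a limit of the assay)
compound 2 `NC(=O)c1c(NC(=O)c2ccccc2Cl)sc2c1CCN(C(=S)Nc1ccccc1Br)C2` — 9090 nM

In a functional assay on HL-60 cells (Homo sapiens) for antiproliferative activity, with a stated time of 24 h (on this read-out higher numbers stand for weaker inhibition and lower numbers for stronger inhibition), compound 2 gives 9090 nM, the only number shown in the series. Going by the values given here, the one further value shown is a limit, that of compound 1. Compound 1 gives only a limit, > 50000 nM, and that limit is recorded in the limit of > 50000 nM in this assay, at which 1 of the 2 values shown sits. Among the compounds with values here, the single measured step, an at least 5.5-fold lower number from compound 1 to compound 2 (0.74 log units; beyond the scatter), concerns the group on the amine nitrogen in the ring and leaves the rest of the molecule untouched.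

Compound 3 `NC(=O)c1c(NC(=O)c2ccccc2C(F)(F)F)sc2c1CCN(C(=S)Nc1ccccc1Br)C2` differs from compound 2 in another place: trifluoromethyl in place of chloro on an aromatic carbon. No measured step touches this position, so nothing in the shown numbers speaks for a change in either direction, and the expected step is one within the scatter, a 1.0-fold lower number from compound 2 to compound 3 (0.00 log units; within the scatter). Compound 3 is therefore estimated at 9000 nM in this assay, with a range from 3000 nM to 30000 nM.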

Compound 3, half-maximal inhibitory concentration: 25500 nM
Estimate against measurement, compound 3: 2.8-fold (0.45 log units) below; measured number inside the range.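

Going by these compounds alone, the position carrying the chloro on the aromatic ring of the amide is read here for the first time: in this assay, trifluoromethyl in place of chloro on an aromatic carbon gives a 2.8-fold higher number from compound 2 to compound 3 (0.45 log units; beyond the scatter) and so shows that this position responds to the group it carries. The step is modest and runs toward weaker inhibition, with the group on the amine nitrogen in the ring held as in compound 2, so chloro is the better of these two groups at this place. Nothing shown gives a measured reason for this step.

As far as these compounds go, how a methoxy, a fluoro or an amine would read at this aromatic carbon remains open. Also open, from the compounds shown here alone, is whether the step would hold with the group of compound 1 on the amine nitrogen in the ring.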